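From 4-methoxyphenyl to 2,3-dimethoxyphenyl on the carbonyl

The compounds below may be only part of what the source reports. "The series", "measured", "known", "first", "only" and "open" are said of these compounds alone.

For the measured compounds named here, in a functional assay on a cell-free system (Platelet, plasma, Homo sapiens) for inhibition (on this read-out higher numbers stand for weaker inhibition and lower numbers for stronger inhibition), compound 1 (`COc1ccc(C(=O)N(CCN2CCC(OCC(=O)O)CC2)c2ccc(C)cc2)cc1`) gives 1200 nM, the lowest number measured so far. Compound 3 (`COc1ccc(C(=O)N(CCN2CCC(OCC(=O)O)CC2)c2ccc(Cl)cc2)cc1`) gives 3100 nM. Compound 2 (`Cc1ccc(N(CCN2CCC(OCC(=O)O)CC2)C(=O)c2ccc(-c3ccccc3)cc2)cc1`) reports only a limit, > 10000 nM.

Compound 4 (`COc1cccc(C(=O)N(CCN2CCC(OCC(=O)O)CC2)c2ccc(C)cc2)c1OC`) carries 2,3-dimethoxyphenyl in place of 4-methoxyphenyl on a carbonyl carbon.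

Going by the values given here, the closest precedent is the replacement of methoxy by phenyl on an aromatic carbon, which gives an at least 8.3-fold higher number from compound 1 to compound 2 (0.92 log units; beyond the scatter). Among the compounds with values here, it is the only measured step that alters the 4-methoxyphenyl group, and its full size is unknown since one end is a limit. The replacement of methyl by chloro on an aromatic carbon gives a 2.6-fold higher number from compound 1 to compound 3 (0.41 log units; beyond the scatter). That change lies elsewhere in the molecule, so it serves only as a guide to how far a single change has moved the number in this series.

Neither step tests a 2,3-dimethoxyphenyl group directly, so the expectation is loose: a modest move towards a higher number, meaning weaker inhibition. The expected step is a 2.1-fold higher number from compound 1 to compound 4 (0.32 log units; beyond the scatter). For compound 4 the estimated value is 2500 nM, with an expected range of 700 nM to 9000 nM.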

Compound 4, half-maximal inhibitory concentration: 1600 nM
The estimate for compound 4 lay 1.6-fold (0.19 log units) above the measured number, and the stated range covers the measured number.
By their numbers in this assay, from the lowest: compounds 1, 4 and 3 (each within the scatter of the next, the first and the last beyond it). At a limit, above all of these: compound 2.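

In this assay the exchange on the carbonyl carbon gives a 1.3-fold higher number from compound 1 to compound 4 (0.12 log units; within the scatter), so this position accepts 2,3-dimethoxyphenyl, with 10 heavy atoms against 8 and a second hydrogen-bond acceptor, without a move that stands clear of the scatter. Enlarging the group here therefore does not by itself carry a cost in this read-out, even though the one earlier change to 4-methoxyphenyl, phenyl in place of methoxy, gives an at least 8.3-fold higher number from compound 1 to compound 2 (0.92 log units; beyond the scatter). The value of compound 2 is a limit, not a number, so that earlier step has a lower bound only: the limit of > 10000 nM in this assay, at which 1 of the 4 values shown sits.

On these data alone, how 2-methoxyphenyl or 3-methoxyphenyl alone would read on the carbonyl carbon remains open, so the two methoxy groups of compound 4 cannot be weighed separately. Also open, as far as these compounds go, is whether 2,3-dimethoxyphenyl would behave the same way with the 4-chlorophenyl group of compound 3 on the amide nitrogen, and whether a primary amide in place of the carboxylic acid would keep any of this inhibition.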